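A few compounds are considered here, and "the series" means these few. Any claim that something is new, unique, unknown or untested is made for them only; others in the source may bear on it.

Working notes on the series. In a physicochemical assay for lipophilicity, at pH 7.4 (on this read-out lower numbers stand for lower lipophilicity and higher numbers for higher lipophilicity), compound 1 `COc1ccc(-c2ccc3ncc(-c4nnco4)c(NCCCn4ccnc4)c3c2)cc1` gives 2.48 and compound 2 `Nc1ccc(-c2ccc3ncc(-c4nnco4)c(NCCCn4ccnc4)c3c2)cc1` gives 2.56, so the two stand level within the scatter. Compound 3 `Cc1ccc(-c2ccc3ncc(-c4nnco4)c(NCCCn4ccnc4)c3c2)cc1` is not yet measured. It departs from compound 2 by methyl in place of amino on an aromatic carbon, para to a large group: methyl in place of amino on an aromatic carbon.

Going by the values given here, only one measured step bears on this change: a number 0.08 log units higher from compound 1 to compound 2 (within the scatter), with amino in place of methoxy on an aromatic carbon. Among the compounds with values here, that step shares the amino group and the position, but no measured compound carries methyl there, so it does not fix the size of the new step. Within the data shown here, the data hold no direct precedent for methyl. Starting from compound 2 at 2.56, a rise beyond the scatter in this assay is expected, since the hydrogen-bond donor and acceptor counted on the amino leave with it, though this reasoning is loose and the range is kept wide. The expected change is a number 0.44 log units higher from compound 2 to compound 3 (beyond the scatter). For compound 3 the estimated value is 3, with an expected range from 2.55 to 3.5.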

Compound 3, distribution coefficient: > 3.5
Compound 3 was reported as a limit; the forecaster's own chance of this, stated with the estimate: 2%; middle value at least 0.50 log units from the limit.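

In this assay compound 3 gives > 3.5, which is a limit of the assay and not a number. On this aromatic carbon, methyl gives a number at least 0.94 log units higher from compound 2 to compound 3 (beyond the scatter), and against methoxy it gives a number at least 1.02 log units higher from compound 1 to compound 3 (beyond the scatter). Going by these compounds alone, the earlier pair showed no separation at this place, with a number 0.08 log units higher from compound 1 to compound 2 (within the scatter), so the position on the ring does respond to a change of group, and methyl is the first group here to move the read-out beyond the scatter.

Going by these compounds, how far compound 3 lies past the limit stays unknown, so the full size of both new steps remains open, and the two cannot be set against each other. On these data alone, it also remains open whether a chlorine atom, a hydroxyl group or a longer chain such as ethyl on the same carbon would read with methyl or stand level with amino and methoxy, and whether the same change would carry over to a core other than the one shared here.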